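A few compounds are considered here, and "the series" means these few. Any claim that something is new, unique, unknown or untested is made for them only; others in the source may bear on it.

Of the compounds shown here, three have been tested so far in a functional assay on P388 cells (Mus musculus) for cytotoxicity, read by MTT assay, with a stated time of 72 h; on this read-out higher numbers stand for weaker inhibition and lower numbers for stronger inhibition. Compound 1 (`C=C1CC[C@]23C(C(=O)OC)=CCC[C@H]2[C@]12C[C@H](c1ccoc1)O[C@H]2O[C@@H]3O`) gives only a limit, >= 10000 nM. Compound 2 (`C=C1CC[C@]23C(C(=O)OC)=CCC[C@H]2[C@]12C[C@H](c1ccoc1)O[C@H]2O[C@H]3O`) also gives only a limit, >= 10000 nM. Compound 3 (`C=C1C[C@H](OC(C)=O)[C@]23C(C(=O)OC)=CCC[C@H]2[C@]12C[C@H](c1ccoc1)O[C@H]2O[C@@H]3O`) carries an acetoxy group that compound 1 lacks. Compound 3 likewise gives only a limit, >= 10000 nM, so it has no exact number of its own.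

Compound 4 (`C=C1C[C@H](OC(C)=O)[C@]23C(C(=O)OC)=CCC[C@H]2[C@]12C[C@H](c1ccoc1)O[C@H]2O[C@H]3O`) is its close partner: the two compounds have the same atoms and bonds and differ only in configuration as drawn: 1 of 7 stereo elements differ; a stereocentre at a saturated ring carbon is drawn S in compound 3 and R in compound 4. For the measured compounds named here, the nearest precedent is the same kind of change, a step that the two limits leave unreadable from compound 1 to compound 2, and the fact that compounds 1 and 2 differ only in the configuration as drawn marks that pair. The acetoxy change, a step that the two limits leave unreadable from compound 1 to compound 3, gives no size either. Going by the values given here, the record therefore consists of the limit of >= 10000 nM in this assay, at which 3 of the 3 values shown sit, with no measured step to suggest that changing this one stereocentre matters. No shift in either direction beyond the usual scatter is expected, and compound 4 may well be reported only as a limit too. The expected step is a number no higher from compound 3 to compound 4 (the limit leaves the size open). For compound 4 the estimated value is 10000 nM, with an expected range from 4000 nM to 30000 nM.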

Compound 4, half-maximal inhibitory concentration: >= 10000 nM
Compound 4: no number, only a limit (the forecaster's own chance of this, stated with the estimate: 85%); the middle value sits exactly at the limit.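

Compound 4, like compound 3 and compound 2, gives only a limit, so neither the stereocentre change nor the acetoxy change yields a readable step. The compounds shown leave open whether either change has any effect in this assay, and what exact values these compounds have.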